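From Phenyl to 3,4,5-Trimethoxyphenyl in a Growth Inhibition Series

The source may report more compounds than this note shows. Statements on the series, on what has been measured and on what is new or still open speak of the compounds shown alone.

Of the compounds shown here, three have been measured so far in a functional assay on COLO 205 cells (Homo sapiens) for inhibition, read by sulforhodamine B assay, with a stated time of 48 h, tested at 50 uM; a higher number here means more inhibition of growth at the concentration tested, a lower number less inhibition of growth. In this assay, compound 1 (`COc1cc(/C=C/C(=O)/C=C/c2ccco2)ccc1OCc1cn(CCCOc2cc(=O)oc3ccccc23)nn1`) gives 59%, compound 2 (`COc1cc(/C=C/C(=O)/C=C/c2cccs2)ccc1OCc1cn(CCOc2cc(=O)oc3ccccc23)nn1`) gives 66%, and compound 3 (`COc1cc(/C=C/C(=O)/C=C/c2ccccc2)ccc1OCc1cn(CCCCOc2cc(=O)oc3ccccc23)nn1`) gives 31%. Compound 3 is the lowest of the three, and its gap to each of the others lies beyond the usual scatter. These three compounds differ from one another in more than one place, so no measured single change is available as a guide.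

Compound 4 (`COc1cc(/C=C/C(=O)/C=C/c2cc(OC)c(OC)c(OC)c2)ccc1OCc1cn(CCCCOc2cc(=O)oc3ccccc23)nn1`) differs from compound 3 in one place: 3,4,5-trimethoxyphenyl in place of phenyl on a double-bonded chain carbon bound to a double-bonded chain carbon. The expectation therefore rests on little, mainly that compound 3, at 31%, leaves room to rise. A moderate increase in this assay is expected, with the estimated step of a number 14 percentage points higher from compound 3 to compound 4 (beyond the scatter). For compound 4, the estimated value is 45%, with an expected range of 25% to 68%.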

Compound 4, percent growth inhibition at one concentration: 60%
For compound 4 the middle estimate is 15 percentage points below the measured one, and the stated range covers the measured number.
By their numbers in this assay, from the lowest: compound 3; then compounds 1, 4 and 2 (each within the scatter of the next).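

For the compounds shown here, at the double-bonded chain carbon bound to a double-bonded chain carbon, putting 3,4,5-trimethoxyphenyl in place of phenyl gives the first single-place comparison, and in this assay the change gives a number 29 percentage points higher from compound 3 to compound 4 (beyond the scatter). This shows that the group held at this position can shift growth inhibition by more than the scatter while the rest of the molecule stays the same. Nothing available here explains why the number rises.

From the compounds shown here alone, it remains open whether all three methoxy groups are needed, or whether a single methoxy group, a fluorine or an amine on the same ring would give a similar step. It is also unknown whether the change would give a step of similar size on a molecule with a shorter chain at the other end.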